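From 4-chlorophenyl to 3,4,5-trifluorophenyl on the shared core

A few compounds are considered here, and "the series" means these few. Any claim that something is new, unique, unknown or untested is made for them only; others in the source may bear on it.

In a functional assay on PBMC cells (Homo sapiens) for inhibition, read by ELISA, BrdU incorporation and thymidine incorporation, with a stated time of 72 h (on this read-out lower numbers stand for stronger inhibition and higher numbers for weaker inhibition), compound 1 (`CC/C(O)=C(\C#N)C(=O)Nc1ccc(-c2ccc(F)cc2)c(C(=O)OC)c1`) gives 2000 nM and compound 2 (`CC/C(O)=C(\C#N)C(=O)Nc1ccc(-c2ccc(Cl)cc2)c(C(=O)OC)c1`) gives 13000 nM, while compound 3 (`CC/C(O)=C(\C#N)C(=O)Nc1ccc(-c2cccc(OC(F)(F)F)c2)c(C(=O)OC)c1`) gives 37000 nM as the highest number of the three. Compound 2 therefore stands second highest.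

The change to compound 4 (`CC/C(O)=C(\C#N)C(=O)Nc1ccc(-c2cc(F)c(F)c(F)c2)c(C(=O)OC)c1`) is 3,4,5-trifluorophenyl in place of 4-chlorophenyl on an aromatic carbon and it sits ortho to a methoxycarbonyl group. Among the compounds with values here, the one measured step that bears on it is a 6.5-fold higher number from compound 1 to compound 2 (0.81 log units; beyond the scatter) for chloro in place of fluoro on an aromatic carbon, a modest step beyond the scatter. The change to compound 4 also removes chloro and brings in fluoro, so a move to a lower number is expected. Within the data shown here, only part of that measured step is expected to return, since no measured compound carries the 3,4,5-trifluorophenyl group. The step expected in this assay is a 2.2-fold lower number from compound 2 to compound 4 (0.34 log units; beyond the scatter) as a modest estimate with wide uncertainty. Compound 4 is estimated at 6000 nM (expected range 1500 nM to 25000 nM).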

Compound 4, half-maximal inhibitory concentration: 19000 nM
For compound 4 the middle estimate is 3.2-fold (0.50 log units) below the measured one, and the stated range covers the measured number.
By their numbers in this assay, from the lowest: compound 1; then compounds 2, 4 and 3 (each within the scatter of the next, the first and the last beyond it).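

Replacing 4-chlorophenyl with 3,4,5-trifluorophenyl at this position gives a 1.5-fold higher number from compound 2 to compound 4 (0.16 log units; within the scatter), so this assay does not separate compound 2 from compound 4 despite the change from one chloro group to three fluoro groups. Fluoro substitution on this ring therefore does not by itself return the low number of compound 1: the move to the 3,4,5-trifluorophenyl group gives a 9.5-fold higher number from compound 1 to compound 4 (0.98 log units; beyond the scatter), and among these comparisons the 4-fluorophenyl group stands apart. The data at hand offer no explanation for either the flat step or the gap to compound 1.

Going by these compounds, it remains open whether the number for compound 1 would hold with a methoxy group or an amine in place of the fluoro group on this ring. On these data alone, the effect of a carboxylic acid in place of the methoxycarbonyl group is also open.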